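Replacing Ethoxy with Trifluoromethyl: Compound 3 to Compound 4

The source may report more compounds than this note shows. Statements on the series, on what has been measured and on what is new or still open speak of the compounds shown alone.

Compound 1 `COc1cc(OC)c(C(=O)/C=C/c2ccc(C(N)=O)cc2)c(OC)c1`: 1790 nM
Compound 2 `COc1cc(OC)c(C(=O)/C=C/c2cccc(C(=O)O)c2)c(OC)c1`: 6760 nM
Compound 3 `CCOc1ccccc1C(=O)/C=C/c1ccccc1`: 609 nM

In a functional assay for inhibition, with Homo sapiens as the target (on this read-out lower numbers stand for stronger inhibition and higher numbers for weaker inhibition), compound 3 stands lowest of the three at 609 nM and its gaps to compound 1 and compound 2 both lie beyond the scatter. Compound 4 `O=C(/C=C/c1ccccc1)c1ccccc1C(F)(F)F` has trifluoromethyl in place of ethoxy on an aromatic carbon and the group sits ortho to a large group. Within the data shown here, no measured pair shows a single change, so the data give no direct guide to this swap. Among the measured compounds shown here, with compound 3 at 609 nM as the lowest number so far, a moderate move toward weaker inhibition in this assay is expected, and the estimated step of a 2.3-fold higher number from compound 3 to compound 4 (0.36 log units; beyond the scatter) probably lies just beyond the scatter. The estimated value for compound 4 is 1400 nM (350 nM to 5000 nM).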

Compound 4, half-maximal inhibitory concentration: 748 nM
The estimate for compound 4 lay 1.9-fold (0.27 log units) above the measured number, and the stated range covers the measured number.
By their numbers in this assay, from the lowest: compounds 3 and 4 (each within the scatter of the next); then compound 1; then compound 2.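

In this assay, trifluoromethyl in place of ethoxy on an aromatic carbon, ortho to a large group, gives a 1.2-fold higher number from compound 3 to compound 4 (0.09 log units; within the scatter) and is the only single-place step among the compounds shown. At this position, then, a group with one hydrogen-bond acceptor and a group with none give values within the scatter of each other. Nothing at hand explains this result. The compounds shown leave open how a bare hydrogen, an amine or a longer alkoxy chain would read at this position, and whether the same swap would give a similar step on the core of compound 1.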